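Propyl amide in place of the chlorophenyl hydrazide

The compounds below may be only part of what the source reports. "The series", "measured", "known", "first", "only" and "open" are said of these compounds alone.

Compound 1 `NNC(=O)c1c(NC(=O)NS(=O)(=O)c2ccccc2)sc2c1CCCCC2`: 1500 nM
Compound 2 `O=C(Nc1sc2c(c1C(=O)NNc1ccc(Cl)cc1)CCCCC2)NS(=O)(=O)c1ccccc1`: 7500 nM

Within the data shown here, in a functional assay on cells (Cancer cell lines, Homo sapiens) for inhibition, with a stated time of 48 h (a lower number here means a stronger inhibitor of growth, a higher number a weaker inhibitor of growth), compound 2 gives the higher of the two numbers; the one measured step, a 5.0-fold higher number from compound 1 to compound 2 (0.70 log units; beyond the scatter), lies beyond the scatter. Compound 3 `CCCNC(=O)c1c(NC(=O)NS(=O)(=O)c2ccccc2)sc2c1CCCCC2` differs from compound 2 by propyl in place of (4-chlorophenyl)amino on an amide-type nitrogen. Among the measured compounds shown here, no measured step matches this change; the only step known removes the 4-chlorophenyl group in the other direction, so the chlorophenyl-free compound 3 is expected to fall between compound 1 and compound 2. For compound 3 the estimate in this assay is 2500 nM (range 800 nM to 8000 nM), an expected step of a 3.0-fold lower number from compound 2 to compound 3 (0.48 log units; beyond the scatter).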

Compound 3, concentration for 50% growth inhibition: 76500 nM
The estimate for compound 3 lay 31-fold (1.49 log units) below the measured number; the measured number lies above the stated range.
By their numbers in this assay, from the lowest: compound 1; then compound 2; then compound 3.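

In this assay, the step of a 10-fold higher number from compound 2 to compound 3 (1.01 log units; beyond the scatter) and the step of a 51-fold higher number from compound 1 to compound 3 (1.71 log units; beyond the scatter) are both large, so at this amide-type nitrogen propyl gives a higher number than either amino or (4-chlorophenyl)amino. The 4-chlorophenyl group had cost only a modest step, so this position is far less forgiving of propyl than of an added aryl group on the amino nitrogen. No measurement given here bears on why. The compounds shown leave open whether the second nitrogen or the propyl chain decides this. An unsubstituted primary amide, a methyl amide or a 4-chlorophenyl amide would separate the two.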